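Swapping chlorine for a silicon-bearing group

A few compounds are considered here, and "the series" means these few. Any claim that something is new, unique, unknown or untested is made for them only; others in the source may bear on it.

Measured in a functional assay on SMMC-7721 cells (Homo sapiens) for antiproliferative activity, read by MTT assay, with a stated time of 48 h; on this read-out lower numbers stand for stronger inhibition and higher numbers for weaker inhibition:
- compound 1 `C=C1/C=C/C(=O)/C(CO)=C\C[C@](C)(CCC=C(C)C)/C=C/[C@H]1OC(=O)C=C(C)C`: 4300 nM
- compound 2 `CC(C)=CCC[C@]1(C)/C=C/[C@@H](OC(=O)C=C(C)C)[C@](C)(O)/C=C/C(=O)/C(CCl)=C\C1`: 840 nM

Compound 2 has the lower number of the two, and its gap to compound 1 lies beyond the scatter. Compound 3 `CC[Si](CC)(CC)C/C1=C/C[C@](C)(CCC=C(C)C)/C=C/[C@@H](OC(=O)C=C(C)C)[C@](C)(O)/C=C/C1=O` changes compound 2 in one place, on a saturated chain carbon bound to a double-bonded ring carbon: a group of 7 heavy atoms (6 carbon, 1 silicon; no ring) in place of one chlorine atom, on a saturated chain carbon bound to a double-bonded ring carbon. Going by the values given here, no measured pair isolates this change. Compound 1 also lacks the chlorine, among other differences, and gives 4300 nM, so a modest loss in this assay, towards higher numbers, is expected. The estimated change is a 2.4-fold higher number from compound 2 to compound 3 (0.38 log units; beyond the scatter). For compound 3 the expected value is 2000 nM, with an estimated range of 700 nM to 6000 nM.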

Compound 3, half-maximal inhibitory concentration: 3460 nM
Beside the measured number, compound 3's estimate is 1.7-fold (0.24 log units) below it; the range from low to high includes it.
By their numbers in this assay, from the lowest: compound 2; then compounds 3 and 1 (each within the scatter of the next).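

In this assay, the group of 7 heavy atoms (6 carbon, 1 silicon) in place of one chlorine atom gives a 4.1-fold higher number from compound 2 to compound 3 (0.61 log units; beyond the scatter). The chlorine can therefore be replaced at this saturated chain carbon by a silicon-bearing group with a modest loss, and compound 3 still has a measurable value. Nothing available explains this loss. From the compounds shown here alone, whether it follows from the silicon atom or from the added atoms in general stays open. Going by these compounds, how a bromine atom, a fluorine atom or an all-carbon chain would compare at this place also stays open.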